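Amide-side variation in a melanocortin receptor 4 binding series

The source may report more compounds than this note shows. Statements on the series, on what has been measured and on what is new or still open speak of the compounds shown alone.

Measured so far:
compound 1 `Cc1ccc(OCC(=O)N2CCN(c3ccc(C(F)(F)F)cc3[C@@H](N)CC(C)C)CC2)cc1`, 4400 nM
compound 2 `CC(C)C[C@H](N)c1cc(C(F)(F)F)ccc1N1CCN(C(=O)CNc2ccccc2)CC1`, 3600 nM

In an assay on HEK293 cells for displacement of a labelled ligand from Melanocortin receptor 4 (Homo sapiens) (a lower number here means a stronger inhibitor, a higher number a weaker inhibitor), compound 1 gives 4400 nM and compound 2 gives 3600 nM. Among the compounds with values here, the single measured step, a 1.2-fold lower number from compound 1 to compound 2 (0.09 log units; within the scatter), lies within the scatter, so compound 2 holds the lower of the two numbers without any order being claimed between them.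

Compound 3 `CCOc1cccc(CC(C)C(=O)N2CCN(c3ccc(C(F)(F)F)cc3[C@@H](N)CC(C)C)CC2)c1` has not been measured in this assay. Its change from compound 2 is 1-(3-ethoxybenzyl)ethyl in place of anilinomethyl on a carbonyl carbon. Within the data shown here, the only step that bears on this position is a 1.2-fold lower number from compound 1 to compound 2 (0.09 log units; within the scatter), an exchange of the group on the carbonyl side that produced no shift beyond the scatter. The present exchange is larger and removes the hydrogen-bond donor, but nothing measured shows the effect of that. The expected step is therefore a 1.0-fold lower number from compound 2 to compound 3 (0.01 log units; within the scatter), essentially none beyond the scatter, with wide uncertainty. Compound 3 is expected to give 3500 nM, between 1200 nM and 10000 nM.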

Compound 3, inhibition constant: 2200 nM
Beside the measured number, compound 3's estimate is 1.6-fold (0.20 log units) above it; the range from low to high includes it.
By their numbers in this assay, from the lowest: compounds 3, 2 and 1 (each within the scatter of the next).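

In this assay the carbonyl position takes 1-(3-ethoxybenzyl)ethyl in place of anilinomethyl with a 1.6-fold lower number from compound 2 to compound 3 (0.21 log units; within the scatter) and in place of (4-methylphenoxy)methyl with a 2.0-fold lower number from compound 1 to compound 3 (0.30 log units; within the scatter) and so no exchange at this position has yet moved the number beyond the scatter. This holds for a group of 12 heavy atoms with 0 hydrogen-bond donors replacing anilinomethyl with 8 heavy atoms and 1 hydrogen-bond donor, so across compound 2 and compound 3 the number shows no dependence on that donor. No evidence on hand accounts for this result.

On these data alone, it remains open which part of 1-(3-ethoxybenzyl)ethyl counts on its own, since the group enters as a whole. Also open, as far as these compounds go, is whether an amine, a carboxylic acid or a longer chain at this carbonyl carbon would produce a step beyond the scatter.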